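Swapping the ring on the chain of compound 1

The compounds below may be only part of what the source reports. "The series", "measured", "known", "first", "only" and "open" are said of these compounds alone.

Compound 1 `O=c1[nH]ccn1CCOc1nn(-c2ccccc2F)c2ccc(F)cc12` gives 200 mL/min/kg in an ADME assay on liver for metabolic stability, with Liver microsome (Homo sapiens) as the target, using microsomes and NADPH, with a stated time of 30 min, tested at 0.5 uM; on this read-out higher numbers stand for fast clearance and lower numbers for slow clearance 
Compound 2 `CC(Oc1nn(-c2ccccc2F)c2ccc(F)cc12)C(=O)N1CCOCC1` gives 317 mL/min/kg in this assay

Compound 1 stands within the usual scatter of compound 2, so these two values set no order. Compound 3 `CN1CCN(CCOc2nn(-c3ccccc3F)c3ccc(F)cc23)C1=O` has not yet been measured. It differs from compound 1 by one change, (a group of 7 heavy atoms (4 carbon, 2 nitrogen, 1 oxygen; one five-membered non-aromatic ring with 2 hetero atoms) in place of a group of 6 heavy atoms (3 carbon, 2 nitrogen, 1 oxygen; one five-membered aromatic ring with 2 hetero atoms), on a saturated chain carbon, two bonds along the chain from an oxygen on an aromatic ring), which brings in 3-methyl-2-oxoimidazolidin-1-yl on a saturated chain carbon, two bonds along the chain from an oxygen on an aromatic ring. For the measured compounds named here, no measured pair shows this change, so in this assay no step beyond the scatter is expected, with only a slight lean towards faster clearance. The expected step of a 1.3-fold higher number from compound 1 to compound 3 (0.10 log units; within the scatter) is an estimate that stays small. For compound 3 the estimated value is 250 mL/min/kg, with an expected range from 130 mL/min/kg to 470 mL/min/kg in this read-out.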

Compound 3, clearance: 1000 mL/min/kg
Compound 3: the middle estimate sits 4.0-fold (0.60 log units) below what was measured, outside the stated range (above it).
By their numbers in this assay, from the lowest: compounds 1 and 2 (each within the scatter of the next); then compound 3.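

On a saturated chain carbon, two bonds along the chain from an oxygen on an aromatic ring, the group matters in this assay: bringing in 3-methyl-2-oxoimidazolidin-1-yl gives a 5.0-fold higher number from compound 1 to compound 3 (0.70 log units; beyond the scatter). For the compounds shown here, the earlier compounds offered no single-place comparison, so this is the first step read at this position. No available measurement bears on what lies behind this step.

As far as these compounds go, the change alters ring and methyl together, and their separate shares remain open. How a primary amine or a carboxylic acid would behave on this chain is also unresolved.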